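Bromo for chloro ortho to the trifluoromethyl: cytotoxicity outlook

This account rests on a few compounds, and the source may have more. Where it says the series, first, only, none or still open, it means among the compounds named here.

In an ADME assay on HEK293 cells (Homo sapiens) for cytotoxicity (on this read-out higher numbers stand for lower toxicity in this test and lower numbers for higher toxicity in this test), compound 1 `Cc1ccc(NCc2cn(-c3ccc(C(=O)O)cc3)nc2-c2ccccc2)cc1Cl` gives 20 ug/mL, and compound 2 `Cc1cc(NCc2cn(-c3ccc(C(=O)O)cc3)nc2-c2ccccc2)ccc1Br` gives 17.9 ug/mL. For compound 3 `O=C(O)c1ccc(-n2cc(CNc3ccc(Cl)c(C(F)(F)F)c3)c(-c3ccccc3)n2)cc1` the test returned only a limit, > 32 ug/mL, and not a number. Compound 3 therefore stands at the top of the three values, on the line described by the limit of > 32 ug/mL in this assay, at which 1 of the 3 values shown sits. The measured steps run a 1.1-fold lower number from compound 1 to compound 2 (0.05 log units; within the scatter), an at least 1.6-fold higher number from compound 1 to compound 3 (0.20 log units; that floor lies within the scatter) and an at least 1.7-fold higher number from compound 2 to compound 3 (0.25 log units; that floor lies within the scatter), so none of the three is established as beyond the scatter. Compound 4 `O=C(O)c1ccc(-n2cc(CNc3ccc(Br)c(C(F)(F)F)c3)c(-c3ccccc3)n2)cc1` differs from compound 3 by bromo in place of chloro on an aromatic carbon. Within the data shown here, the closest precedent is the exchange of chloro for bromo between compound 1 and compound 2, which stayed within the scatter in this assay; the two steps that reach compound 3 give only floors. No step beyond the scatter is therefore expected from compound 3 to compound 4 in this assay, that is a number no higher from compound 3 to compound 4 (the limit leaves the size open). Compound 4 is estimated at 32 ug/mL, with a range from 20 ug/mL to 64 ug/mL, and a limit rather than a number is the likelier outcome.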

Compound 4, half-maximal cytotoxic concentration: > 32 ug/mL
Compound 4: only a limit was reported (the forecaster's own chance of this, stated with the estimate: 60%); the middle value sits exactly at the limit.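

In this assay compound 4 also returns only a limit, > 32 ug/mL, so bromo on this carbon, ortho to a trifluoromethyl group, leaves the read-out at the same limit as chloro: the limit of > 32 ug/mL in this assay, at which 2 of the 4 values shown sit.

The step between the two limits cannot be read. The readable steps are an at least 1.7-fold higher number from compound 2 to compound 4 (0.25 log units; that floor lies within the scatter) and an at least 1.6-fold higher number from compound 1 to compound 4 (0.20 log units; that floor lies within the scatter); both are floors, so neither establishes a change beyond the scatter.

On these data alone, the true values of compound 3 and compound 4 remain open, and with them whether chloro and bromo differ at this position at all. Also open, as far as these compounds go, is whether a nitrile or a methoxy group on this carbon would stay at the same limit in this assay.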